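A few compounds are considered here, and "the series" means these few. Any claim that something is new, unique, unknown or untested is made for them only; others in the source may bear on it.

Measured compounds in a functional assay on L02 cells (Homo sapiens) for inhibition, read by MTT assay, with a stated time of 48 h; a higher number here means a weaker inhibitor, a lower number a stronger inhibitor:
- compound 1, `COc1ccc2c(=O)c(/C=C/C(=O)NCc3ccc(F)cc3)coc2c1`: > 200000 nM
- compound 2, `COc1ccc2c(=O)c(/C=C/C(=O)NCc3ccccc3F)coc2c1`: > 200000 nM

Compound 2 stands at a limit of this assay rather than at a number; its value of > 200000 nM is a limit. The same holds for compound 1, whose value of > 200000 nM is also a limit. Among the compounds with values here, the one measured step, a step that the two limits leave unreadable from compound 1 to compound 2, therefore cannot be read, and the limit of > 200000 nM in this assay, at which 2 of the 2 values shown sit, is all the evidence there is for the series. Neither compound shows inhibition inside the measurable range of this assay.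

Compound 3, `COc1ccc(NC(=O)/C=C/c2coc3cc(OC)ccc3c2=O)cc1`, differs from compound 2 in one place: 4-methoxyphenyl in place of 2-fluorobenzyl on an amide-type nitrogen. Within the data shown here, no measured step bears directly on this change, since the only step is unreadable. With both measured compounds sitting at the limit in this assay, compound 3 is expected to sit there as well, and the expected step that the limit leaves unreadable from compound 2 to compound 3 is no more than a guess around that limit. The estimate for compound 3 in this assay is 300000 nM, expected to fall between 100000 nM and 1000000 nM, most likely reported again only as a limit.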

Compound 3, half-maximal inhibitory concentration: > 200000 nM
Compound 3: no number, only a limit; the forecaster's own chance of this, stated with the estimate: 80%; the middle value is on the limit's open side.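

In this assay compound 3 gives > 200000 nM, which is a limit and not a number. The steps from compound 1 and from compound 2 to compound 3 cannot be read, because all three compounds stand at the same limit: the limit of > 200000 nM in this assay, at which 3 of the 3 values shown sit.

The compounds shown leave open whether the groups on the amide-type nitrogen differ in their effect at all.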